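Swapping Fluoro for Trifluoromethyl in Compound 3

A few compounds are considered here, and "the series" means these few. Any claim that something is new, unique, unknown or untested is made for them only; others in the source may bear on it.

Of the compounds shown here, two have so far been tested in a functional assay on A-375 cells (Homo sapiens) for antiproliferative activity, read by MTT assay, with a stated time of 24 h, tested at 1.23 ug/mL; a higher number here means a stronger effect of the compound at the concentration tested, a lower number a weaker effect. Compound 1 `Cc1c(C(=O)Nc2c(F)cc(-c3cccc(F)c3)cc2F)nc2ccc(F)cc2c1O` carries a hydroxy group on an aromatic carbon of its core, and in this assay compound 1 gives 2.34%. Compound 2 `Cc1c(C(=O)Nc2c(F)cc(-c3cccc(F)c3)cc2F)nc2ccc(F)cc2c1C(=O)O` differs only by carrying a carboxy group in place of that hydroxy, and in this assay compound 2 gives 16.3%. Among the compounds with values here, the single step between them, a number 14 percentage points higher from compound 1 to compound 2 (beyond the scatter), lies beyond the usual scatter. Compound 2 therefore stands highest of the two numbers, with compound 1 as the nearest and lower one.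

Compound 3 `Cc1c(C(=O)Nc2c(F)cc(-c3cccc(F)c3)cc2F)nc2ccc(C(F)(F)F)cc2c1C(=O)O` keeps the carboxy group of compound 2 and changes a different spot: trifluoromethyl in place of fluoro on an aromatic carbon. Within the data shown here, no measured step involves this kind of change; the only step known concerns the hydroxy-to-carboxy exchange, so it gives no guide to the size or direction of this one. The expectation is therefore a step of a number 0.3 percentage points lower from compound 2 to compound 3 (within the scatter), not beyond the scatter. Compound 3 is estimated at 16% in this assay, within a range from 4% to 34%.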

Compound 3, a percentage reported as inhibition, at one concentration (the size of the read-out at that concentration, not a potency): 18.3%
Beside the measured number, compound 3's estimate is 2.3 percentage points below it; measured number inside the range.
By their numbers in this assay, from the lowest: compound 1; then compounds 2 and 3 (each within the scatter of the next).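

In this assay, within the data shown here, trifluoromethyl in place of fluoro gives a number 2 percentage points higher from compound 2 to compound 3 (within the scatter), the first reading for this position on the shared core, since the only earlier step concerned the exchange of hydroxy for carboxy at a different spot. Here 1 heavy atom gives way to 4 heavy atoms on an aromatic carbon of the fused system, yet at this single tested concentration the read-out does not separate the two compounds, so with the carboxy group in place this exchange leaves no mark that can be told from ordinary repeat variation. Nothing available offers an explanation for this outcome, so it stands as an observation only.

From the compounds shown here alone, only fluoro and trifluoromethyl have been seen at this position, and both were seen alongside the carboxy group, so it remains open whether trifluoromethyl would read the same in the hydroxy compound. Other groups here, such as a chlorine atom, a methoxy group, an amine or a longer alkyl chain, could show whether this position can move the read-out at all, given that neither compound reaches a large inhibition at this concentration.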